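Turning one double bond from E to Z

This account rests on a few compounds, and the source may have more. Where it says the series, first, only, none or still open, it means among the compounds named here.

- compound 1 `COc1cc(/C=C\c2cn(C(C)=O)c3ccccc23)cc(OC)c1OC` gives 2850 nM
- compound 2 `COc1cc(/C=C\c2c[nH]c3ccccc23)cc(OC)c1OC` gives 3230 nM
- compound 3 `COc1cc(/C=C/c2cn(C)c3ccccc23)cc(OC)c1OC` gives 3090 nM

In a functional assay on HT-29 cells (Homo sapiens) for inhibition (a lower number here means a stronger inhibitor, a higher number a weaker inhibitor), these three values lie within the usual scatter of one another, so compound 3 stands level with the other two. Compound 4 `COc1cc(/C=C\c2cn(C)c3ccccc23)cc(OC)c1OC` differs from it only in geometry (the two compounds have the same atoms and bonds and differ only in configuration as drawn: 1 of 1 stereo elements differ; a double bond is drawn E in compound 3 and Z in compound 4). For the measured compounds named here, no measured pair tests this change directly. Going by the values given here, the one measured step (a 1.1-fold higher number from compound 1 to compound 2 (0.05 log units; within the scatter)) concerns the group on the aromatic nitrogen, and it stayed within the scatter. Compound 1 (2850 nM) and compound 2 (3230 nM) have the double bond drawn Z, as compound 4 does, yet they sit level with compound 3 (3090 nM), where it is drawn E. No step beyond the scatter is therefore expected (a 1.2-fold lower number from compound 3 to compound 4 (0.09 log units; within the scatter)), although the missing direct pair keeps the range wide. Compound 4 is estimated at 2500 nM (range 500 nM to 6000 nM).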

Compound 4, half-maximal inhibitory concentration: 3090 nM
For compound 4 the middle estimate is 1.2-fold (0.09 log units) below the measured one, within the range that was stated.
By their numbers in this assay, from the lowest: compounds 1, 3, 4 and 2 (each within the scatter of the next).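

In this assay the geometry of the double bond now has a direct test, which gives no change at the digits printed from compound 3 to compound 4 (within the scatter), and one fact keeps that test clean: the fact that compounds 3 and 4 differ only in the configuration as drawn

With the double bond drawn Z, methyl in place of hydrogen on the aromatic nitrogen gives a 1.0-fold lower number from compound 2 to compound 4 (0.02 log units; within the scatter), and methyl in place of acetyl gives a 1.1-fold higher number from compound 1 to compound 4 (0.04 log units; within the scatter). Neither the geometry nor these three nitrogen groups separate the compounds here.

Open, on these data alone, is whether the E form stays level with hydrogen or acetyl on that nitrogen. Also open, as far as these compounds go, is whether a benzyl group there would move the number beyond the scatter.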